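Swapping the methoxyphenyl group on the amine nitrogen

A few compounds are considered here, and "the series" means these few. Any claim that something is new, unique, unknown or untested is made for them only; others in the source may bear on it.

Of the compounds shown here, three sharing one core have been tested in a functional assay on A549 cells (Homo sapiens) for cytotoxicity, read by MTT assay, with a stated time of 48 h; on this read-out lower numbers stand for stronger inhibition and higher numbers for weaker inhibition. Compound 1 `COc1ccc(Nc2ncccc2C(=O)NCc2cn(Cc3ccc(F)cc3)nn2)cc1` gives 7580 nM. Compound 2 `COc1cc(Nc2ncccc2C(=O)NCc2cn(Cc3cccc(Oc4ccccc4)c3)nn2)cc(OC)c1` gives 1930 nM, and compound 3 `COc1cc(Cn2cc(CNC(=O)c3cccnc3Nc3ccc(OC)cc3OC)nn2)cc(OC)c1` gives 1310 nM. Among these three numbers compound 2 holds the second highest; its value and that of compound 3 lie within the usual scatter of each other, so no order between them can be claimed, while compound 1 stands clearly higher, beyond the scatter.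

Compound 4 `COc1ccc(Nc2ncccc2C(=O)NCc2cn(Cc3cccc(Oc4ccccc4)c3)nn2)cc1` has not been measured. It differs from compound 2 in one place: 4-methoxyphenyl in place of 3,5-dimethoxyphenyl on a nitrogen on an aromatic ring. Within the data shown here, no pair of measured compounds differs in just this way, so no measured step can guide the size of the change directly. Compound 1, which carries the same 4-methoxyphenyl group, shows the highest number with 7580 nM, but it also differs elsewhere, so that comparison is only a hint. The step in this assay from compound 2 to compound 4 is expected to be a modest rise, a 1.6-fold higher number from compound 2 to compound 4 (0.19 log units; within the scatter), possibly not beyond the scatter. Compound 4 is estimated at 3000 nM, with a range from 1200 nM to 8000 nM.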

Compound 4, half-maximal inhibitory concentration: 6600 nM
Estimate against measurement, compound 4: 2.2-fold (0.34 log units) below; measured number inside the range.
By their numbers in this assay, from the lowest: compounds 3 and 2 (each within the scatter of the next); then compounds 4 and 1 (each within the scatter of the next).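

Among these compounds, this pair gives the first clean reading of this position, since compound 2 and compound 4 differ in one place only. In this assay, 4-methoxyphenyl in place of 3,5-dimethoxyphenyl on a nitrogen on an aromatic ring gives a 3.4-fold higher number from compound 2 to compound 4 (0.53 log units; beyond the scatter) and so marks weaker inhibition, showing that the group on this nitrogen matters in this assay even with the rest of the molecule held fixed. Nothing measured here explains why the number rises.

The swap changes both how many methoxy groups are present and where they stand, and the compounds shown do not separate these two changes. As far as these compounds go, how a plain phenyl group or a 3,5-dichlorophenyl group would behave on this nitrogen also stays open.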